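The source may report more compounds than this note shows. Statements on the series, on what has been measured and on what is new or still open speak of the compounds shown alone.

Measured so far in an assay on U2OS cells for inhibition of secreted frizzled-related protein 1 (Homo sapiens), read by a luciferase reporter, with a stated time of 18 h; on this read-out lower numbers stand for an effect already at smaller amounts and higher numbers for an effect only at larger amounts of compound:
- compound 1, `O=C(O)c1ccc(S(=O)(=O)N2CCC(NS(=O)(=O)c3cc(S(=O)(=O)c4ccccc4)ccc3C(F)(F)F)CC2)cc1`: 110 nM
- compound 2, `N#Cc1cccc(S(=O)(=O)N2CCC(NS(=O)(=O)c3cc(S(=O)(=O)c4ccccc4)ccc3C(F)(F)F)CC2)c1`: 170 nM
- compound 3, `CC(C)(O)CCN1CCC(NS(=O)(=O)c2cc(S(=O)(=O)c3ccccc3)ccc2C(F)(F)F)CC1`: 630 nM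

Compound 3 stands highest of the three numbers in this assay; its nearest neighbour is compound 2 and its furthest is compound 1, and both gaps lie beyond the scatter. The two steps that lead to it, a 5.7-fold higher number from compound 1 to compound 3 (0.76 log units; beyond the scatter) and a 3.7-fold higher number from compound 2 to compound 3 (0.57 log units; beyond the scatter), are both modest and both point the same way: exchanging an arylsulfonyl on the ring nitrogen for the 3-hydroxy-3-methylbutyl chain raises the number. Between compounds 1 and 2 the change is within the scatter, a 1.5-fold higher number from compound 1 to compound 2 (0.19 log units; within the scatter).

Compound 4, `O=C(CC1CCNCC1)N1CCC(NS(=O)(=O)c2cc(S(=O)(=O)c3ccccc3)ccc2C(F)(F)F)CC1`, is not yet measured. It differs from compound 3 by ((piperidin-4-yl)methyl)carbonyl in place of 3-hydroxy-3-methylbutyl on an amine nitrogen in a ring. Within the data shown here, none of the measured steps exchanges one non-aryl substituent on that nitrogen for another, so the two steps into compound 3 bear on it only indirectly. The expectation is a step of a 1.3-fold lower number from compound 3 to compound 4 (0.10 log units; within the scatter), close to none beyond the scatter, with a slight lean towards a lower number. Compound 4 is therefore estimated at 500 nM, with a range from 150 nM to 1800 nM.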

Compound 4, half-maximal effective concentration: 210 nM
The estimate for compound 4 lay 2.4-fold (0.38 log units) above the measured number, within the range that was stated.
By their numbers in this assay, from the lowest: compounds 1, 2 and 4 (each within the scatter of the next); then compound 3.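

In this assay this ring nitrogen now shows a difference between two groups that are not arylsulfonyl: ((piperidin-4-yl)methyl)carbonyl in place of 3-hydroxy-3-methylbutyl gives a 3.0-fold lower number from compound 3 to compound 4 (0.48 log units; beyond the scatter) as a modest gain. Set against the arylsulfonyl compounds, the same group gives a 1.2-fold higher number from compound 2 to compound 4 (0.09 log units; within the scatter) and a 1.9-fold higher number from compound 1 to compound 4 (0.28 log units; within the scatter), so an arylsulfonyl on this nitrogen is not required for numbers in this range. The earlier rise on leaving the arylsulfonyl therefore holds for compound 3 and not for compound 4, and no measurement on hand accounts for the difference.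

Still open, on these data alone, is whether the gain follows the carbonyl or the piperidine ring, which 3-hydroxy-3-methylbutanoyl and cyclohexylacetyl on the same nitrogen would separate. Also open, as far as these compounds go, is how a shorter acyl group such as acetyl would compare.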